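The compounds below may be only part of what the source reports. "The series", "measured", "known", "first", "only" and "open" are said of these compounds alone.

The measured compounds are compound 1 `Cc1cc(C#N)cc(C)c1Oc1ccnc(S(=O)(=O)CC(=O)Nc2ccccc2)n1` with 29300 nM and compound 2 `Cc1ccc(NC(=O)CS(=O)(=O)c2nccc(Oc3c(C)cc(C#N)cc3C)n2)cc1` with 7490 nM in an ADME assay on MT4 cells (Homo sapiens) for cytotoxicity, read by MTT assay, with a stated time of 4 days; a lower number here means that less compound is tolerated, a higher number that more compound is tolerated.

Among these two numbers compound 2 stands lowest; its only neighbour is compound 1, and the step of a 3.9-fold lower number from compound 1 to compound 2 (0.59 log units; beyond the scatter) is the single measured change in this assay. Compound 3 `Cc1cc(C#N)cc(C)c1Oc1ccnc(S(=O)(=O)CC(=O)Nc2cccc(Cl)c2)n1` has not yet been measured. It differs from compound 2 by 3-chlorophenyl in place of 4-methylphenyl on an amide-type nitrogen. Among the measured compounds shown here, only the step from compound 1 to compound 2 bears on this change, since it alters the same aromatic ring, but it concerns a methyl and a hydrogen rather than a chlorine, so it offers only a loose guide. The 3-chlorophenyl ring is therefore expected to leave the number near that of compound 2, with a modest upward step a 1.6-fold higher number from compound 2 to compound 3 (0.20 log units; within the scatter) considered most likely, not clearly beyond the scatter. Compound 3 is estimated at 12000 nM, in a range from 4000 nM to 36000 nM.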

Compound 3, half-maximal cytotoxic concentration: 25400 nM
Compound 3: the middle estimate sits 2.1-fold (0.33 log units) below what was measured, within the range that was stated.
By their numbers in this assay, from the lowest: compound 2; then compounds 3 and 1 (each within the scatter of the next).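

In this assay, the change on the amide-type nitrogen gives a 3.4-fold higher number from compound 2 to compound 3 (0.53 log units; beyond the scatter), so the lower number of compound 2 does not carry over to a ring bearing a chlorine. Chloro in place of hydrogen gives a 1.2-fold lower number from compound 1 to compound 3 (0.06 log units; within the scatter), which places the 3-chlorophenyl ring level with the unsubstituted phenyl ring within the scatter, and among these three compounds only the 4-methylphenyl ring of compound 2 stands apart. Nothing given here accounts for this difference between the two substituted rings.

The compounds shown include neither a 4-chlorophenyl nor a 3-methylphenyl ring, so the effect of the group cannot be separated from that of its place on the ring. From the compounds shown here alone, how an amine or a carboxylic acid on this ring would stand also remains open.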